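A few compounds are considered here, and "the series" means these few. Any claim that something is new, unique, unknown or untested is made for them only; others in the source may bear on it.

The measured compounds:
Compound 1, `S=C(Nc1ccccc1)N1N=C(c2ccc(Cl)cc2)CC1c1ccc2c(c1)OCCO2`, in a functional assay on HCT-116 cells (Homo sapiens) for antiproliferative activity, read by MTT assay, with a stated time of 48 h (on this read-out higher numbers stand for weaker inhibition of growth and lower numbers for stronger inhibition of growth), gives only a limit of the assay, > 200000 nM.
Compound 2, `S=C(Nc1ccccc1)N1N=C(c2ccc(Br)cc2)CC1c1ccc2c(c1)OCCO2`, gives 32100 nM.
Compound 3, `S=C(Nc1ccccc1)N1N=C(c2ccccc2Br)CC1c1ccc2c(c1)OCCO2`, gives 195000 nM.

Compound 3 stands at the highest of the two numbers shown; compound 2 is nearest, and the step of a 6.1-fold higher number from compound 2 to compound 3 (0.78 log units; beyond the scatter) came with 2-bromophenyl in place of 4-bromophenyl on the carbon with a double bond to nitrogen. Compound 1 sits at the limit of the limit of > 200000 nM in this assay, at which 1 of the 3 values shown sits, so its relation to compound 3 is read only as an at least 1.0-fold lower number from compound 1 to compound 3 (0.01 log units; that floor lies within the scatter).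

Compound 4, `COc1ccccc1C1=NN(C(=S)Nc2ccccc2)C(c2ccc3c(c2)OCCO3)C1`, differs from compound 3 by methoxy in place of bromo on an aromatic carbon. Among the compounds with values here, the two measured steps concern a change of halogen, an at least 6.2-fold lower number from compound 1 to compound 2 (0.79 log units; beyond the scatter), and a change of the position of bromine, a 6.1-fold higher number from compound 2 to compound 3 (0.78 log units; beyond the scatter); neither replaces a halogen with methoxy, and no measured step touches a methoxy group at all. The expectation therefore rests on compound 3 alone, and for compound 4 the step of a 1.3-fold lower number from compound 3 to compound 4 (0.11 log units; within the scatter) is estimated to stay within the scatter. Compound 4 is expected to give 150000 nM, with a range from 40000 nM to 400000 nM.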

Compound 4, concentration for 50% growth inhibition: > 200000 nM
Compound 4: a limit, no number (the forecaster's own chance of this, stated with the estimate: 35%); middle value at least 1.3-fold (0.12 log units) from the limit.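

Compound 4 gives only a limit of the assay in this assay, and it joins compound 1 there: the limit of > 200000 nM in this assay, at which 2 of the 4 values shown sit. With methoxy on this aromatic carbon, ortho to a large group, the change from bromo gives an at least 1.0-fold higher number from compound 3 to compound 4 (0.01 log units; that floor lies within the scatter), so the data do not order the two groups at this position, while an at least 6.2-fold higher number from compound 2 to compound 4 (0.79 log units; beyond the scatter) shows that 2-methoxyphenyl, like the 2-bromophenyl of compound 3, falls short of the 4-bromophenyl of compound 2. Two different groups at this position have now left growth inhibition weak, yet compound 1, with 4-chlorophenyl, also sits at the limit and goes against tying weak inhibition to this position alone, and the step between compound 1 and compound 4 cannot be read.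

Going by these compounds, whether an amine or a carboxylic acid at this position would give a readable number remains open. So does whether methoxy in the place that bromo holds in compound 2 would keep the number of compound 2 or lose it.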